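The source may report more compounds than this note shows. Statements on the series, on what has been measured and on what is new or still open speak of the compounds shown alone.

Three compounds have been measured in a functional assay on HCT-8 cells (Homo sapiens) for antiproliferative activity, read by sulforhodamine B assay, with a stated time of 3 days; a lower number here means that less compound is needed, a higher number that more compound is needed for the effect:
compound 1, `CCCC1=C(OC)C(CCC)(CCC)C(=O)/C(=C(O)\C=C\c2ccc(I)cc2)C1=O`, gives 1.1 uM;
compound 2, `CCCC1=C(OCC)C(CCC)(CCC)C(=O)/C(=C(O)\C=C\c2ccccc2)C1=O`, gives 5.6 uM;
compound 3, `COC1=C(CC(C)C)C(=O)/C(=C(O)/C=C/c2ccccc2)C(=O)C1(CC(C)C)CC(C)C`, gives 7.5 uM.

Among these three numbers compound 2 stands second highest. Its nearest neighbour is compound 3, whose number lies within the scatter of that of compound 2, so the two are not distinguishable. Compound 1 is the furthest away, with a number that is lower than that of compound 2 and beyond the scatter.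

Compound 4, `CCCC1=C(OC)C(CCC)(CCC)C(=O)/C(=C(O)\C=C\c2ccccc2)C1=O`, has not yet been measured in this assay. It differs from compound 2 in one place: hydrogen in place of methyl on a saturated chain carbon bound to an oxygen on an unsaturated carbon. Going by the values given here, no pair of measured compounds shows this change, so there is nothing to calibrate it against. In this assay a step of this kind is expected to be small, none beyond the scatter, in either direction. The expected step is a 1.2-fold lower number from compound 2 to compound 4 (0.09 log units; within the scatter). Compound 4 is estimated at 4.5 uM, with a range from 1.5 uM to 12 uM.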

Compound 4, concentration for half-maximal effect: 3.5 uM
Estimate against measurement, compound 4: 1.3-fold (0.11 log units) above, within the range that was stated.
By their numbers in this assay, from the lowest: compound 1; then compounds 4, 2 and 3 (each within the scatter of the next, the first and the last beyond it).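

In this assay the ether chain can now be read as a single change: ethoxy to methoxy gives a 1.6-fold lower number from compound 2 to compound 4 (0.20 log units; within the scatter) and so the two compounds cannot be told apart. The aromatic carbon gives the clearer result, as hydrogen in place of iodo there gives a 3.2-fold higher number from compound 1 to compound 4 (0.50 log units; beyond the scatter) and this modest step lies beyond the scatter. Still open, as far as these compounds go, is how a longer chain on that oxygen would read, and whether chloro or an amine on the aromatic carbon would match iodo. Nothing shown here gives a reason for either step.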